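Urea chain variation in an aminothiazole guanidine series

The source may hold more compounds than are shown below. What is called first, only, known or untested is meant among the compounds shown, and "the series" means these compounds.

Compound 2 `CCCCCCNC(=O)/N=C(\N)NCCCc1sc(N)nc1C` carries a hexyl urea on the shared core. In a functional assay on membranes from Sf9 cells for agonist activity at histamine H2 receptor (Homo sapiens), read by scintillation counting and GTPgammaS binding, with a stated time of 90 min (on this read-out higher numbers stand for an effect only at larger amounts of compound and lower numbers for an effect already at smaller amounts), compound 2 gives 38.9 nM. Compound 1 `Cc1nc(N)sc1CCCN/C(N)=N/C(=O)NCC(C)CCc1ccccc1` has a branched chain that ends in a phenyl ring on the same core; in this assay compound 1 gives 29.5 nM. Compound 2 stands together with compound 1 here: the two numbers lie within the scatter of each other, so no order between them can be read from the data.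

Compound 3 `Cc1nc(N)sc1CCCN/C(N)=N/C(=O)NCC(C)C1CCCCC1` has not yet been measured in this assay. It differs from compound 2 in one place: 1-cyclohexylethyl in place of pentyl on a saturated chain carbon bound to an amide-type nitrogen. Among the measured compounds shown here, no measured pair isolates this change, so the expectation rests on compound 1, whose chain likewise branches and ends in a ring and which gives 29.5 nM. On that basis the change is expected to move the number little, within the scatter or at most slightly towards an effect at smaller amounts; the step from compound 2 to compound 3 is estimated as a 1.6-fold lower number from compound 2 to compound 3 (0.19 log units; within the scatter). For compound 3 in this assay the estimate is 25 nM, with a range from 8 nM to 80 nM.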

Compound 3, half-maximal effective concentration: 21.9 nM
Estimate against measurement, compound 3: 1.1-fold (0.06 log units) above, within the range that was stated.
By their numbers in this assay, from the lowest: compounds 3, 1 and 2 (each within the scatter of the next).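

In this assay, 1-cyclohexylethyl in place of pentyl on a saturated chain carbon bound to an amide-type nitrogen gives a 1.8-fold lower number from compound 2 to compound 3 (0.25 log units; within the scatter), so this position takes a branched chain carrying a six-membered non-aromatic ring of carbon only, with no step beyond the scatter from the straight-chain urea. Cyclohexyl in place of phenethyl on a saturated chain carbon bound to two saturated chain carbons gives a 1.3-fold lower number from compound 1 to compound 3 (0.13 log units; within the scatter), so the number also stays within the scatter when the chain of compound 1 loses its phenyl ring and ends in a saturated ring instead. Nothing at hand bears on why these numbers lie so close together.

Going by these compounds, what remains open is whether this tolerance extends to chains of another kind, such as a chain ending in a primary amine or a carboxylic acid, or a much shorter methyl group. The three compounds shown all carry hydrocarbon chains of similar size and fall within the scatter of one another, so they do not show where on this chain the number begins to move.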